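Aryl piperazine dithiocarbamate benzamides: pyrazinyl for pyridinyl

This account rests on a few compounds, and the source may have more. Where it says the series, first, only, none or still open, it means among the compounds named here.

Three compounds of the shared core have numbers in a functional assay on HeLa cells (Homo sapiens) for antiproliferative activity, read by CCK-8 assay, with a stated time of 72 h, tested at 2 uM; on this read-out higher numbers stand for a stronger effect at the one concentration tested and lower numbers for a weaker effect. Compound 1 `Nc1ccccc1NC(=O)c1ccc(CSC(=S)N2CCN(c3ccccc3)CC2)cc1` gives 62.2%. Compound 2 `COc1ccc(N2CCN(C(=S)SCc3ccc(C(=O)Nc4ccccc4N)cc3)CC2)cc1`, carrying methoxy in place of hydrogen on an aromatic carbon, gives 39.4%, the step being a number 22.8 percentage points lower from compound 1 to compound 2 (beyond the scatter). Compound 3 `Nc1ccccc1NC(=O)c1ccc(CSC(=S)N2CCN(c3ccncc3)CC2)cc1`, with pyridin-4-yl in place of phenyl on an amine nitrogen in a ring, gives 77%; the corresponding step is a number 14.8 percentage points higher from compound 1 to compound 3 (beyond the scatter), and against the methoxy compound it is a number 37.6 percentage points higher from compound 2 to compound 3 (beyond the scatter). Compound 3 thus stands highest of the three numbers, with compound 1 nearest and compound 2 furthest, both gaps beyond the scatter.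

Compound 4 `Nc1ccccc1NC(=O)c1ccc(CSC(=S)N2CCN(c3cnccn3)CC2)cc1` is the next entry. It differs from compound 3 by pyrazin-2-yl in place of pyridin-4-yl on an amine nitrogen in a ring. Among the compounds with values here, no measured step exchanges one six-membered aromatic ring with hetero atoms for another. The nearest guide is a number 14.8 percentage points higher from compound 1 to compound 3 (beyond the scatter), a modest rise, while a number 22.8 percentage points lower from compound 1 to compound 2 (beyond the scatter) shows that a change on the aryl group can also pull the read-out down by a modest amount. Given compound 3 at 77%, the step of a number 9 percentage points lower from compound 3 to compound 4 (within the scatter) is expected to be small, at or near the scatter, with a slight downward lean. Compound 4 is therefore estimated at 68%, within a range from 50% to 85%.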

Compound 4, a percentage reported as inhibition, at one concentration (the size of the read-out at that concentration, not a potency): 70.4%
Compound 4: middle estimate off by 2.4 percentage points, on the low side, and the stated range covers the measured number.
By their numbers in this assay, from the lowest: compound 2; then compounds 1, 4 and 3 (each within the scatter of the next, the first and the last beyond it).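

In this assay, exchanging one six-membered aromatic ring with hetero atoms for another at this ring nitrogen, with 2 hetero atoms in place of 1, gives a number 6.6 percentage points lower from compound 3 to compound 4 (within the scatter), so this change does not separate the two compounds. Against the unsubstituted phenyl, the pyrazin-2-yl group gives a number 8.2 percentage points higher from compound 1 to compound 4 (within the scatter), whereas the pyridin-4-yl group gives a number 14.8 percentage points higher from compound 1 to compound 3 (beyond the scatter), so a hetero atom in this ring does not by itself guarantee a step beyond the scatter, even though compound 3 and compound 4 cannot be told apart. The pyrazin-2-yl group also stands well clear of the 4-methoxyphenyl group, with a number 31 percentage points higher from compound 2 to compound 4 (beyond the scatter), showing that the large gap to compound 2 is not confined to the pyridin-4-yl group.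

Nothing available here explains these numbers or the difference between the two hetero rings. Still open, going by these compounds, is how a pyrimidin-2-yl ring, a pyridin-2-yl ring or a simple methyl on the same ring nitrogen would read at this one concentration, and whether the compounds that cannot be separated here would also stay together across a range of concentrations.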